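Inverting both stereocentres of compound 3

The source may report more compounds than this note shows. Statements on the series, on what has been measured and on what is new or still open speak of the compounds shown alone.

Compound 1 `CC(=O)Nc1cnc2[nH]c(=O)n([C@H]3CC[C@@H](C(C)C)CC3)c(=O)c2c1`: 10 mL.min-1.g-1
Compound 2 `CC(C)(C)[C@H]1CC[C@@H](n2c(=O)[nH]c3ncc(N)cc3c2=O)CC1`: 1.6 mL.min-1.g-1
Compound 3 `CC(C)[C@H]1CC[C@H](n2c(=O)[nH]c3ncc(N)cc3c2=O)CC1`: 1.9 mL.min-1.g-1

The measure here is an ADME assay on microsomes from liver (Mus musculus, strain CD1) for metabolic stability, read by HPLC, using NADPH, with a stated time of 30 min, tested at 0.5 uM (on this read-out higher numbers stand for fast clearance and lower numbers for slow clearance), and all three compounds have a value in it. Compound 3 (1.9 mL.min-1.g-1) lies within the usual scatter of compound 2 (1.6 mL.min-1.g-1) and clearly under compound 1 (10 mL.min-1.g-1). The next compound is compound 4 `CC(C)[C@H]1CC[C@@H](n2c(=O)[nH]c3ncc(N)cc3c2=O)CC1` and its change from compound 3 is this: the two compounds have the same atoms and bonds and differ only in configuration as drawn: 2 of 2 stereo elements differ (all stereocentres are inverted: mirror images); a stereocentre at a saturated ring carbon is drawn r in compound 3 and s in compound 4; a stereocentre at a saturated ring carbon is drawn r in compound 3 and s in compound 4 with nothing leaving and nothing entering. Going by the values given here, no measured pair here shows what such an inversion does. In this assay no step beyond the scatter is expected, and the estimated move is a 1.1-fold higher number from compound 3 to compound 4 (0.02 log units; within the scatter) at most a small one. For compound 4 the expected value is 2 mL.min-1.g-1 with an estimated range from 1 mL.min-1.g-1 to 4.5 mL.min-1.g-1 for now.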

Compound 4, intrinsic clearance in microsomes: 4.8 mL.min-1.g-1
Estimate against measurement, compound 4: 2.4-fold (0.38 log units) below, and the stated range ends below it.
By their numbers in this assay, from the lowest: compounds 2 and 3 (each within the scatter of the next); then compound 4; then compound 1.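

The arrangement at the saturated ring carbons alone moves clearance in this assay, with a 2.5-fold higher number from compound 3 to compound 4 (0.40 log units; beyond the scatter), because nothing else changes: the fact that compounds 3 and 4 differ only in the configuration as drawn. With this configuration in place, hydrogen in place of methyl on the saturated chain carbon gives a 3.0-fold higher number from compound 2 to compound 4 (0.48 log units; beyond the scatter). Hydrogen in place of acetyl on the aromatic ring nitrogen gives a 2.1-fold lower number from compound 1 to compound 4 (0.32 log units; beyond the scatter).

As far as these compounds go, it remains open whether the same inversion would give a similar step in a compound carrying the acetyl group. It is also unknown how a carboxylic acid or a longer chain on the saturated ring would behave.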